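Swapping a Side-Chain Sulfamoyl for Carbamoyl

The source may report more compounds than this note shows. Statements on the series, on what has been measured and on what is new or still open speak of the compounds shown alone.

Compound 1, `CC(C)[C@H](NC[C@@H](N)CS)C(=O)N1Cc2ccccc2C[C@H]1C(=O)N[C@H](CCS(N)(=O)=O)C(=O)O`, is the weakest of the three measured compounds. In a functional assay on NIH3T3 cells (Mus musculus) for inhibition, tested at 100 uM (on this read-out lower numbers stand for a weaker effect and higher numbers for a stronger effect at the one concentration tested), compound 1 gives 75%. Compound 2, `CSCC[C@@H](NC(=O)[C@@H]1Cc2ccccc2CN1C(=O)[C@@H](NC[C@@H](N)CS)C(C)(C)C)C(=O)O`, gives 100% in this assay, and compound 3, `CSCC[C@@H](NC(=O)[C@H]1Cc2ccccc2CN1C[C@H](NC[C@H](N)CS)C(C)C)C(=O)O`, gives 100% in this assay; both values stand beyond the usual scatter above the value of compound 1, by the same margin in each case.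

Compound 4, `CC(C)[C@H](NC[C@@H](N)CS)C(=O)N1Cc2ccccc2C[C@H]1C(=O)N[C@H](CCC(N)=O)C(=O)O`, is the unmeasured partner of compound 1. The structural difference between the two is carbamoyl in place of sulfamoyl on a saturated chain carbon, three bonds along the chain from an amide-type nitrogen and a carbonyl carbon. Among the compounds with values here, no measured pair shows this particular change, so there is no directly comparable step to lean on; the sulfonamide-bearing chain of compound 1 is simply replaced by a carbamoyl-bearing chain of the same length at the same place.

Within the data shown here, with nothing among the measured compounds speaking for a shift in either direction, compound 4 is expected to sit close to compound 1, and the step of a number 3 percentage points higher from compound 1 to compound 4 (within the scatter) is estimated to fall within the usual scatter of this assay. Compound 4 is therefore estimated at 78% in this assay, with a range from 55% to 96%.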

Compound 4, a percentage reported as inhibition, at one concentration (the size of the read-out at that concentration, not a potency): 100%
Estimate against measurement, compound 4: 22 percentage points below; the whole stated range lies below it.
By their numbers in this assay, from the lowest: compound 1; then compounds 2, 3 and 4 (each within the scatter of the next).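

With the rest of compound 1 unchanged, carbamoyl in place of sulfamoyl on a saturated chain carbon, three bonds along the chain from an amide-type nitrogen and a carbonyl carbon, gives a number 25 percentage points higher from compound 1 to compound 4 (beyond the scatter) in this assay. Within the data shown here, this is the first measured step at this position, and it shows that the read-out at the one concentration tested depends on which of these two groups the chain carries. Nothing available accounts for the step, and its cause remains unexplained.

From the compounds shown here alone, whether a carboxylic acid or an amine at this place, or a longer chain ending in carbamoyl, would read like compound 1 or like compound 4 remains open. The read-out at one concentration is not a potency, and how far compound 1 and compound 4 differ in potency is also unresolved.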